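Methyl in place of chloro on compound 2

The source may report more compounds than this note shows. Statements on the series, on what has been measured and on what is new or still open speak of the compounds shown alone.

In an assay on isolated protein for inhibition of AP2-associated protein kinase 1 (Homo sapiens), with a stated time of 3 h, in the presence of a further agent that is not named here (a lower number here means a stronger inhibitor, a higher number a weaker inhibitor), compound 2 `COC(=O)Nc1cc(-c2cc(Cl)c(OC[C@@](C)(N)CC(C)C)cn2)ccn1` gives 1.1 nM, the second highest of the three numbers. Compound 3 `CC(=O)Nc1cc(-c2ccc(OC[C@@H](N)CC(C)C)c(Cl)c2)ccn1` gives 0.5 nM, and compound 1 `COC(=O)Nc1cc(-c2ccc(OC[C@@](C)(N)CC(C)C)cn2)ccn1` gives 23 nM. The step of a 21-fold lower number from compound 1 to compound 2 (1.32 log units; beyond the scatter) came from chloro in place of hydrogen on an aromatic carbon. Compound 4 `COC(=O)Nc1cc(-c2cc(C)c(OC[C@@](C)(N)CC(C)C)cn2)ccn1` differs from compound 2 by methyl in place of chloro on an aromatic carbon, with the methyl entering on the same aromatic carbon, ortho to the (2-amino-2,4-dimethylpentyl)oxy group and opposite the ring nitrogen. Among the measured compounds shown here, only the step from compound 1 to compound 2 bears on this position; it shows a substituent there is strongly favoured over hydrogen, but no pair compares methyl with chloro. A modest step is expected, most likely a somewhat higher number, a 2.3-fold higher number from compound 2 to compound 4 (0.36 log units; beyond the scatter). Compound 4 is estimated at 2.5 nM, within 0.8 nM to 8 nM.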

Compound 4, half-maximal inhibitory concentration: 1.7 nM
Beside the measured number, compound 4's estimate is 1.5-fold (0.17 log units) above it; measured number inside the range.
By their numbers in this assay, from the lowest: compound 3; then compounds 2 and 4 (each within the scatter of the next); then compound 1.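

In this assay, the exchange at this position reads as a 1.5-fold higher number from compound 2 to compound 4 (0.19 log units; within the scatter), so methyl and chloro on this aromatic carbon cannot be told apart here. Methyl also shows a 14-fold lower number from compound 1 to compound 4 (1.13 log units; beyond the scatter), so the large difference from hydrogen is not confined to chloro among the substituents shown. No measured evidence bears on the reason for this.

From the compounds shown here alone, whether a larger group on this carbon, such as methoxy, ethyl or a longer chain, would fit the same pattern stays open. So does the effect of an amine or a nitrile there.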